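Swapping 3-hydroxyphenyl for 2-methylphenyl on an aromatic nitrogen

The source may hold more compounds than are shown below. What is called first, only, known or untested is meant among the compounds shown, and "the series" means these compounds.

In a functional assay on A549 cells (Homo sapiens) for inhibition, read by MTT assay, with a stated time of 24 h (a higher number here means a weaker inhibitor, a lower number a stronger inhibitor), compound 2 `CC1(C)[C@H]2CC[C@]1(C)N(Cc1cn(-c3cccc(O)c3)nn1)C(=O)C2` gives 180 nM and compound 1 `CC1(C)[C@H]2CC[C@]1(C)N(Cc1cn(-c3ccccc3C#N)nn1)C(=O)C2` gives 100 nM in the same read-out, so these two lie within the scatter of each other. Compound 3 `Cc1ccccc1-n1cc(CN2C(=O)C[C@@H]3CC[C@@]2(C)C3(C)C)nn1` keeps the shared core and differs from compound 2 in one group (2-methylphenyl in place of 3-hydroxyphenyl on an aromatic nitrogen). Within the data shown here, the one measured step at this aromatic nitrogen is a 1.8-fold higher number from compound 1 to compound 2 (0.26 log units; within the scatter) and it stayed within the scatter. Given that single small step, no change beyond the scatter is expected in this assay in either direction, and the estimated step is only a 1.2-fold lower number from compound 2 to compound 3 (0.08 log units; within the scatter) for now. For compound 3 the estimated value is 150 nM with an expected range from 60 nM to 380 nM around it.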

Compound 3, half-maximal inhibitory concentration: 90 nM
Estimate against measurement, compound 3: 1.7-fold (0.22 log units) above; measured number inside the range.
By their numbers in this assay, from the lowest: compounds 3, 1 and 2 (each within the scatter of the next).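

The step from the 3-hydroxyphenyl to the 2-methylphenyl group is a 2.0-fold lower number from compound 2 to compound 3 (0.30 log units; within the scatter) in this assay, so swapping a group with 1 hydrogen-bond donor for one with 0 hydrogen-bond donors gives no readable change. Methyl in place of cyano on an aromatic carbon gives a 1.1-fold lower number from compound 1 to compound 3 (0.05 log units; within the scatter), so all three groups on this aromatic nitrogen stay within the scatter of the next. No available evidence explains this. Still open, on these data alone, is whether any group here can move the number beyond the scatter, such as a phenyl ring carrying an amine or a carboxylic acid.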